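The source may hold more compounds than are shown below. What is called first, only, known or untested is meant among the compounds shown, and "the series" means these compounds.

Measured compounds in the series:
- compound 1 `COc1ccc(-c2nc(C(=O)/C=C\Nc3ccc(Cl)cc3)c3ccccn23)cc1` — a functional assay on A549 cells (Homo sapiens) for cytotoxicity, read by MTT assay, with a stated time of 48 h; on this read-out higher numbers stand for weaker inhibition and lower numbers for stronger inhibition: "not determined" (no result reported)
- compound 2 `O=C(/C=C\Nc1ccc(Cl)cc1)c1nc(-c2ccc(C(F)(F)F)cc2)n2ccccc12` — 18500 nM
- compound 3 `O=C(/C=C\Nc1ccc(Cl)cc1)c1nc(-c2ccc(F)cc2)n2ccccc12` — 5090 nM

Compound 1 stands without a number in this assay, so its place among the measured compounds cannot be fixed. Of the two compounds that do carry numbers, compound 2 gives 18500 nM and compound 3 gives 5090 nM in this assay; the step of a 3.6-fold lower number from compound 2 to compound 3 (0.56 log units; beyond the scatter) is the only one recorded, and it concerns fluoro in place of trifluoromethyl on an aromatic carbon of the ring attached to the shared core, not the aniline side.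

Compound 4 `COc1ccc(-c2nc(C(=O)/C=C\Nc3ccc(F)cc3)c3ccccn23)cc1` differs from compound 1 by fluoro in place of chloro on an aromatic carbon. For the measured compounds named here, no measured pair shows this chloro-to-fluoro exchange on the (4-chlorophenyl)amino part, and compound 1 itself has no value, so there is nothing that bears on the step directly. Going by the values given here, the only guide is the range spanned by compound 2 and compound 3, which share the chloro aniline and differ from compound 4 elsewhere. Given that, the expectation is a number in this assay of the same order as those two, with no direction that can be stated beyond the scatter.

Compound 4 is therefore estimated at 8000 nM in this assay, with a range of 2000 nM to 40000 nM.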

Compound 4, half-maximal inhibitory concentration: > 30000 nM
Compound 4 ended at the assay's limit (the forecaster's own chance of this, stated with the estimate: 15%); middle value at least 3.7-fold (0.57 log units) away from the limit.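

In this assay compound 4 gives > 30000 nM, which is a limit of the assay and not a number. Compound 1 carries no number here, so no step can be read between compound 1 and compound 4. The compounds shown leave open what fluoro in place of chloro does to this read-out when the rest of the structure stays the same.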